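The compounds below may be only part of what the source reports. "The series", "measured", "known", "first", "only" and "open" are said of these compounds alone.

Measured so far:
- Compound 1, `CC(Sc1nnc(-c2ccncc2)s1)C(=O)Nc1ccc(Cl)cc1Cl`: > 50000 nM in an ADME assay on HepG2 cells (Homo sapiens) for cytotoxicity, with a stated time of 3 days; a higher number here means that more compound is tolerated, a lower number that less compound is tolerated
- Compound 2, `O=C(CSc1nnc(-c2ccncc2)s1)Nc1ccc(Cl)cc1Cl`: "not determined" (no result reported) in this assay

In this assay compound 1 reaches only the upper limit of the test, > 50000 nM, so no exact number exists for it. Among the measured compounds shown here, for compound 2 the outcome in this assay is "not determined" (no result reported), which means it stands nowhere on the scale yet; the one value available among the two, that of compound 1, sits at the limit of > 50000 nM in this assay, at which 1 of the 2 values shown sits. Compound 3, `O=C(CSc1nnc(-c2ccncc2)s1)Nc1ccccc1Cl`, differs from compound 2 by hydrogen in place of chloro on an aromatic carbon. For the measured compounds named here, with no measured step between any two compounds, there is no basis to expect a change in this assay beyond the usual scatter, in either direction. On the strength of compound 1 reaching (the limit of > 50000 nM in this assay, at which 1 of the 2 values shown sits), compound 3 is expected to come out around 50000 nM in this assay, with a likely range from 15000 nM to 150000 nM, and most probably as a limit rather than a number.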

Compound 3, half-maximal cytotoxic concentration: > 50000 nM
Compound 3: only a limit was reported (the forecaster's own chance of this, stated with the estimate: 75%); the middle value sits exactly at the limit.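

Among the compounds shown here, compound 3 reaches only a limit in this assay, > 50000 nM, and compound 2 has no reported result there, so no step between compound 2 and compound 3 can be read. Still open is what concentration any of these compounds needs to harm the cells, and whether replacing chloro with hydrogen changes it.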